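The source may report more compounds than this note shows. Statements on the series, on what has been measured and on what is new or still open speak of the compounds shown alone.

Compound 1 `O=C(O)C(=O)CC(=O)c1ccccc1Cl` is the reference point of this short series. In an assay on isolated protein for inhibition of Flap endonuclease 1 (Homo sapiens) (on this read-out higher numbers stand for weaker inhibition and lower numbers for stronger inhibition), compound 1 gives 3510 nM, the lowest of the three numbers recorded. Compound 3 `O=C(O)C(=O)CC(=O)c1cccc(-c2ccccc2)c1` sits beside it: in this assay compound 3 gives 3620 nM, and the two values lie within the scatter of each other, so nothing separates them. Within the data shown here, compound 2 `Cc1ccccc1C(=O)CC(=O)C(=O)O` is the one measured compound that differs from compound 1 in a single place; in this assay compound 2 gives 12900 nM, and the step from a 3.7-fold higher number from compound 1 to compound 2 (0.57 log units; beyond the scatter) is the only step on record.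

The unmeasured compound 4 `O=C(O)C(=O)CC(=O)c1c(Cl)cccc1Cl` also differs from compound 1 in one place: chloro in place of hydrogen on an aromatic carbon. Among the measured compounds shown here, no measured pair shows a chloro entering in place of hydrogen; the one known step concerns the exchange of the existing chloro for methyl, which is a different change, so it bears on compound 4 only loosely, by showing that the chloro-bearing position is sensitive at all. For the measured compounds named here, with no direct precedent, compound 4 is expected to land near compound 1, with a step from a 1.0-fold lower number from compound 1 to compound 4 (0.00 log units; within the scatter) that may fall within the scatter. The estimate for compound 4 in this assay is 3500 nM, expected to lie between 1200 nM and 10000 nM.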

Compound 4, half-maximal inhibitory concentration: 37900 nM
Beside the measured number, compound 4's estimate is 11-fold (1.03 log units) below it, outside the stated range (above it).
By their numbers in this assay, from the lowest: compounds 1 and 3 (each within the scatter of the next); then compound 2; then compound 4.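

The ring carbon that carries hydrogen in compound 1, ortho to a group of 8 heavy atoms and meta to a chloro group, turns out not to be a free place for substitution. In this assay the entry of a single chloro gives an 11-fold higher number from compound 1 to compound 4 (1.03 log units; beyond the scatter) and so moves the read-out towards weaker inhibition. The earlier step, a 3.7-fold higher number from compound 1 to compound 2 (0.57 log units; beyond the scatter), only exchanged one group for another at the chloro-bearing carbon and was modest, whereas this one adds a heavy atom at a carbon that had none and is large, which shows that a second chloro on the ring of compound 1 is not tolerated as neutral in this read-out. Nothing on record explains the loss.

The compounds shown leave open whether a fluoro, a methyl, a methoxy or an amine on this same carbon would raise the number as the chloro does, or whether the effect is peculiar to chloro. They also leave open whether a chloro placed on any other ring carbon of compound 1 would behave in the same way.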